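Nitrophenylsulfonate in place of benzoate on the shared core

The source may hold more compounds than are shown below. What is called first, only, known or untested is meant among the compounds shown, and "the series" means these compounds.

Compound 1 `O=C(c1ccc(Cl)c(C(F)(F)F)c1)N1CCC(n2cncc2-c2ccc(OS(=O)(=O)c3ccccc3)cc2)CC1`: 702 nM in an assay on HEK293 cells for antagonist activity at P2X purinoceptor 7 (Homo sapiens), read by fluorescence, with a stated time of 2 h; on this read-out lower numbers stand for stronger inhibition and higher numbers for weaker inhibition
Compound 2 `O=C(Oc1ccc(-c2cncn2C2CCN(C(=O)c3ccc(Cl)c(C(F)(F)F)c3)CC2)cc1)c1ccccc1`: > 10000 nM in this assay, a limit of the assay and not a number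
Compound 3 `O=C(c1ccc(Cl)c(C(F)(F)F)c1)N1CCC(n2cncc2-c2ccc(OS(=O)(=O)c3cccs3)cc2)CC1`: 238 nM in this assay

Compound 2 stands at the limit of this assay (the limit of > 10000 nM in this assay, at which 1 of the 3 values shown sits), and only compound 2 does so. Compound 4 `O=C(c1ccc(Cl)c(C(F)(F)F)c1)N1CCC(n2cncc2-c2ccc(OS(=O)(=O)c3cccc([N+](=O)[O-])c3)cc2)CC1` differs from compound 2 in one place: (3-nitrophenyl)sulfonyl in place of benzoyl on an oxygen on an aromatic ring. Going by the values given here, two measured steps bear on this change: an at least 14-fold higher number from compound 1 to compound 2 (1.15 log units; beyond the scatter), and an at least 42-fold lower number from compound 2 to compound 3 (1.62 log units; beyond the scatter), both beyond the scatter. Both show that a sulfonyl linker in place of the benzoyl brings a measurable number, and compound 4 keeps a sulfonyl linker. The step of an at least 20-fold lower number from compound 2 to compound 4 (1.30 log units; beyond the scatter) is therefore expected to be large and downward. Compound 4 is expected to give about 500 nM in this assay, within a range from 150 nM to 2000 nM.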

Compound 4, half-maximal inhibitory concentration: 249 nM
Beside the measured number, compound 4's estimate is 2.0-fold (0.30 log units) above it; measured number inside the range.
By their numbers in this assay, from the lowest: compounds 3 and 4 (each within the scatter of the next); then compound 1. At a limit, above all of these: compound 2.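

On the oxygen on the aromatic ring, a third sulfonyl group again brings a measurable number, with an at least 40-fold lower number from compound 2 to compound 4 (1.60 log units; beyond the scatter). Compound 2 is now the only one of the four at a limit of the assay, which is not a number: the limit of > 10000 nM in this assay, at which 1 of the 4 values shown sits. On the sulfonyl sulfur, 3-nitrophenyl and thiophen-2-yl cannot be told apart, with a 1.0-fold higher number from compound 3 to compound 4 (0.02 log units; within the scatter), while nitro in place of hydrogen on an aromatic carbon gives a 2.8-fold lower number from compound 1 to compound 4 (0.45 log units; beyond the scatter).

The compounds shown leave open whether an amine or a carboxylic acid in place of the nitro would give a similar number.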